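Trifluoromethoxy in place of trifluoromethyl: working notes

A few compounds are considered here, and "the series" means these few. Any claim that something is new, unique, unknown or untested is made for them only; others in the source may bear on it.

In a functional assay on DWD cells (Homo sapiens) for inhibition, read by sulforhodamine B assay (on this read-out lower numbers stand for stronger inhibition of growth and higher numbers for weaker inhibition of growth), compound 1 (`c1ccc(-c2ccc(-c3ccc(-c4nc5ccccc5[nH]4)cc3)cc2)cc1`) gives 100000 nM, compound 2 (`Fc1ccc(-c2ccc(-c3ccc(-c4nc5ccccc5[nH]4)cc3)cc2)cc1`) gives 35600 nM and compound 3 (`FC(F)(F)c1ccc(-c2ccc(-c3ccc(-c4nc5ccccc5[nH]4)cc3)cc2)cc1`) gives 100000 nM. Compound 3 thus stands level with compound 1, together the highest number of the three. Compound 4 (`FC(F)(F)Oc1ccc(-c2ccc(-c3ccc(-c4nc5ccccc5[nH]4)cc3)cc2)cc1`) carries trifluoromethoxy in place of trifluoromethyl on an aromatic carbon, para to a large group: trifluoromethoxy in place of trifluoromethyl on an aromatic carbon. The nearest evidence is no change at the digits printed from compound 1 to compound 3 (within the scatter), and a 2.8-fold higher number from compound 2 to compound 3 (0.45 log units; beyond the scatter). The only shift to a lower number is modest: a 2.8-fold lower number from compound 1 to compound 2 (0.45 log units; beyond the scatter). In this assay a step no larger than these is therefore expected, most likely within the scatter. The estimated step is a 1.4-fold lower number from compound 3 to compound 4 (0.15 log units; within the scatter). For compound 4 the estimated value is 70000 nM, with an expected range of 25000 nM to 100000 nM.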

Compound 4, concentration for 50% growth inhibition: 100000 nM
The estimate for compound 4 lay 1.4-fold (0.15 log units) below the measured number; low and high end bracket the measured number.
By their numbers in this assay, from the lowest: compound 2; then compounds 1, 3 and 4 (each within the scatter of the next).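

In this assay trifluoromethoxy in place of trifluoromethyl gives no change at the digits printed from compound 3 to compound 4 (within the scatter) and trifluoromethoxy in place of hydrogen gives no change at the digits printed from compound 1 to compound 4 (within the scatter) on this aromatic carbon, para to a large group. Trifluoromethoxy in place of fluoro gives a 2.8-fold higher number from compound 2 to compound 4 (0.45 log units; beyond the scatter) and leaves compound 2 as the only one of the four set apart beyond the scatter. No measurement shown accounts for this pattern.

Open, as far as these compounds go, is whether chloro on this carbon would track fluoro, and whether an amine or a carboxylic acid there would separate from compound 1.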